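The source may report more compounds than this note shows. Statements on the series, on what has been measured and on what is new or still open speak of the compounds shown alone.

Measured in a toxicity assay on KB cells (Homo sapiens) for cytotoxicity, read by fluorescence, with a stated time of 3 days; on this read-out higher numbers stand for an effect only at larger amounts of compound and lower numbers for an effect already at smaller amounts:
- Compound 1 `CCCCOC(=O)CNC(=O)[C@H](CSc1ccc([N+](=O)[O-])cc1[N+](=O)[O-])NC(=O)CC[C@H](NC(=O)c1ccccc1)C(=O)OCCCC`: > 300 uM, a limit
- Compound 2 `CCCCOC(=O)CNC(=O)[C@H](CSc1ccc([N+](=O)[O-])cc1[N+](=O)[O-])NC(=O)CC[C@H](NC(C)=O)C(=O)OCCCC`: > 300 uM, a limit

Neither entry is a number. From the compounds shown here alone, compound 2 stands with compound 1 at the limit of > 300 uM in this assay, at which 2 of the 2 values shown sit, so its true position is unknown.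

The next change gives compound 3 `CCCCOC(=O)CNC(=O)[C@H](CSc1ccc([N+](=O)[O-])cc1[N+](=O)[O-])NC(=O)CC[C@H](Nc1nc(N)nc(Cl)n1)C(=O)OCCCC`: 4-amino-6-chloro-1,3,5-triazin-2-yl in place of acetyl on an amine nitrogen, (4-amino-6-chloro-1,3,5-triazin-2-yl in place of acetyl on an amine nitrogen).

Among the measured compounds shown here, only one measured step bears on this, as it also alters the acyl group: a step that the two limits leave unreadable from compound 1 to compound 2. Going by these compounds, it has no size to carry over, so the direction in this assay remains open. A reading at the limit is slightly more likely than a number. Any number would have to fall at lower values, and the range is kept wide for that reason.

The expected change is an at least 1.5-fold lower number from compound 2 to compound 3 (0.17 log units; that floor lies within the scatter). For compound 3 the estimate is 200 uM, with an expected range of 50 uM to 400 uM.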

Compound 3, concentration for half-maximal effect: > 300 uM
Compound 3 ended at the assay's limit; the forecaster's own chance of this, stated with the estimate: 55%; middle value at least 1.5-fold (0.17 log units) from the limit.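

Compound 3 gives > 300 uM in this assay, which is a limit. No step among compound 1, compound 2 and compound 3 can be read: the limit of > 300 uM in this assay, at which 3 of the 3 values shown sit.

Still open, from the compounds shown here alone, is whether benzoyl, acetyl or 4-amino-6-chloro-1,3,5-triazin-2-yl on the amine nitrogen makes any difference to the read-out.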